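The source may report more compounds than this note shows. Statements on the series, on what has been measured and on what is new or still open speak of the compounds shown alone.

Working notes on a urea series in a functional assay on HepG2 cells (Homo sapiens) for inhibition, read by MTT assay, with a stated time of 120 h; a lower number here means a stronger inhibitor, a higher number a weaker inhibitor.

Compound 1 `CC(NC(=O)C#Cc1ccc(NC(=O)Nc2cc(C(F)(F)F)ccc2Cl)cc1)c1ccccc1` and compound 2 `CC(NC(=O)C#Cc1ccc(NC(=O)Nc2ccc(Cl)c(C(F)(F)F)c2)cc1)c1ccccc1` share a core; compound 3 `CC(NC(=O)c1ccc(-c2ccc(NC(=O)Nc3cc(C(F)(F)F)ccc3Cl)cc2)cc1)c1ccccc1` and compound 4 `CC(NC(=O)c1ccc(-c2ccc(NC(=O)Nc3ccc(Cl)c(C(F)(F)F)c3)cc2)cc1)c1ccccc1` share another. How the core of compound 3 differs from the core of compound 1 is not broken down here.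

In this assay compound 1 gives 19000 nM. Compound 2 gives 20500 nM. The step between them is a 1.1-fold higher number from compound 1 to compound 2 (0.03 log units; within the scatter), a change described as 4-chloro-3-(trifluoromethyl)phenyl in place of 2-chloro-5-(trifluoromethyl)phenyl on an amide-type nitrogen. Compound 3 gives 18400 nM; its value and the values of compound 1 and compound 2 all lie within the scatter of one another, so no order among the three is claimed.

Compound 4 is not yet measured. It differs from compound 3 by 4-chloro-3-(trifluoromethyl)phenyl in place of 2-chloro-5-(trifluoromethyl)phenyl on an amide-type nitrogen. Among the measured compounds shown here, this is the same kind of change as the one from compound 1 to compound 2, made at the same kind of place, an amide-type nitrogen whose other neighbour is a carbonyl carbon, though on a different core.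

For compound 4 the step from compound 3 is expected to be a 1.1-fold higher number from compound 3 to compound 4 (0.04 log units; within the scatter), because the same change once gave a 1.1-fold higher number from compound 1 to compound 2 (0.03 log units; within the scatter), a step within the scatter. The expectation rests on that single precedent and on the value of compound 3, 18400 nM, as the starting point. Compound 4 is thus estimated at 20000 nM, with a range from 10000 nM to 40000 nM.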

Compound 4, half-maximal inhibitory concentration: 16800 nM
Compound 4: the middle estimate sits 1.2-fold (0.08 log units) above what was measured, and the stated range covers the measured number.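

In this assay, putting 4-chloro-3-(trifluoromethyl)phenyl in place of 2-chloro-5-(trifluoromethyl)phenyl on the amide-type nitrogen of the core of compound 3 gives a 1.1-fold lower number from compound 3 to compound 4 (0.04 log units; within the scatter), so the change has no readable effect on this core. Set beside the earlier step, the new one does not differ from it, and the two cores agree in showing no readable effect of this change: the same change on two cores in this assay, a 1.1-fold higher number (0.03 log units; within the scatter) from compound 1 to compound 2 and a 1.1-fold lower number (0.04 log units; within the scatter) from compound 3 to compound 4, 1.2-fold (0.07 log units) apart, within the scatter of two such steps This shows only that the swap between these two groups stays within the scatter on both cores; the opposite directions of the two steps carry no meaning, and two steps this small cannot show whether a change with a real effect would carry from one core to the other.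

Open, going by these compounds, is whether the number in this assay would move at all with a different group on that ring, such as an amine or a carboxylic acid in place of the trifluoromethyl, or a plain phenyl carrying neither chlorine nor trifluoromethyl. Also open, on these data alone, is whether the swap stays this small on any core other than those of compound 1 and compound 3.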